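The compounds below may be only part of what the source reports. "The series", "measured", "known", "first", "only" and "open" are said of these compounds alone.

Of the compounds shown here, three that share one core have been tested in a functional assay on A-375 cells (Homo sapiens) for antiproliferative activity, read by CCK-8 assay, with a stated time of 72 h, tested at 2 uM; a lower number here means a weaker effect, a higher number a stronger effect of the compound at the concentration tested. Compound 1 `Nc1ccccc1NC(=O)c1ccc(CSC(=S)N2CCN(Cc3ccccn3)CC2)cc1` gives 20.7%. Compound 2 `Nc1ccccc1NC(=O)c1ccc(CSC(=S)N2CCN(c3ccc(Cl)cc3)CC2)cc1` gives 32.2%, and compound 3 `Nc1ccccc1NC(=O)c1ccc(CSC(=S)N2CCN(c3ccccc3)CC2)cc1` gives 27.5%. Among the measured steps, a number 11.5 percentage points higher from compound 1 to compound 2 (beyond the scatter), while a number 6.8 percentage points higher from compound 1 to compound 3 (within the scatter) and a number 4.7 percentage points lower from compound 2 to compound 3 (within the scatter). Compound 3 therefore holds the second highest of the three numbers, yet its gaps to compound 2 and to compound 1 both lie within the scatter, so no order among these three can be read from them.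

Compound 4 `Nc1ccccc1NC(=O)c1ccc(CSC(=S)N2CCN(c3cccnc3)CC2)cc1` differs from compound 3 in a single place: pyridin-3-yl in place of phenyl on an amine nitrogen in a ring. Going by the values given here, no measured step makes this exact exchange. The nearest comparison, a number 6.8 percentage points higher from compound 1 to compound 3 (within the scatter), also trades a pyridine-containing group for phenyl, but that group is (pyridin-2-yl)methyl rather than pyridin-3-yl, so it is a different change and stayed within the scatter. The step of a number 4.7 percentage points lower from compound 2 to compound 3 (within the scatter) shows that altering the group on this ring nitrogen need not move the read-out beyond the scatter either. On this basis the expected step of a number 0.5 percentage points lower from compound 3 to compound 4 (within the scatter) is small, with no change beyond the scatter in either direction. Compound 4 is therefore estimated at 27%, within a range from 15% to 40%.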

Compound 4, a percentage reported as inhibition, at one concentration (the size of the read-out at that concentration, not a potency): 40.5%
For compound 4 the middle estimate is 13.5 percentage points below the measured one, and the stated range ends below it.
By their numbers in this assay, from the lowest: compounds 1, 3, 2 and 4 (each within the scatter of the next, the first and the last beyond it).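

In this assay, replacing one ring carbon of the phenyl with nitrogen to give pyridin-3-yl produces a number 13 percentage points higher from compound 3 to compound 4 (beyond the scatter), so a single atom in the group on this amine nitrogen can move the read-out beyond the scatter, which the step between the two phenyl-type groups did not do. A pyridine ring alone does not account for this, as the (pyridin-2-yl)methyl group also contains one and the comparison shows a number 19.8 percentage points higher from compound 1 to compound 4 (beyond the scatter), whereas a number 8.3 percentage points higher from compound 2 to compound 4 (within the scatter) leaves the pyridin-3-yl and 4-chlorophenyl groups without a readable order. No measurement shown here explains why this exchange raises the number.

On these data alone, it remains open whether the ring nitrogen must sit where it does in pyridin-3-yl, which pyridin-2-yl or pyridin-4-yl attached directly to the amine nitrogen would test, and whether a second ring nitrogen, as in pyrimidin-5-yl, would raise the number further. These read-outs also come from one concentration, so they tell only of a stronger or weaker effect at that concentration for all four compounds.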